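The source may report more compounds than this note shows. Statements on the series, on what has been measured and on what is new or still open speak of the compounds shown alone.

Compound 1 `Fc1cccc(Nc2nc(-c3cccc(F)c3)nc3ccc(F)cc23)c1`: in a functional assay on HT29-AK cells (Homo sapiens) for cytotoxicity, read by MTT assay, with a stated time of 48 h (a lower number here means a stronger inhibitor, a higher number a weaker inhibitor), compound 1 gives > 50000 nM, which is a limit of the assay and not a number.
Compound 2 `Fc1cccc(-c2nc(Nc3cccc(Cl)c3)c3cc(F)ccc3n2)c1`: compound 2 gives > 50000 nM, again a limit.
Compound 3 `Oc1cccc(Nc2nc(-c3cccc(F)c3)nc3ccc(F)cc23)c1`: compound 3 gives > 50000 nM, also a limit.

Compound 2 therefore stands only at a limit, and so do the other two measured compounds, as the shared limit of > 50000 nM in this assay, at which 3 of the 3 values shown sit, shows. The step from compound 2 to compound 4 `Nc1cccc(Nc2nc(-c3cccc(F)c3)nc3ccc(F)cc23)c1` is a change at one place on the shared core: amino in place of chloro on an aromatic carbon.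

The measured steps that touch the same place are a step that the two limits leave unreadable from compound 2 to compound 3, a step that the two limits leave unreadable from compound 1 to compound 2 and a step that the two limits leave unreadable from compound 1 to compound 3. None of them has a readable size, because every value involved sits at the limit of > 50000 nM in this assay, at which 3 of the 3 values shown sit. The measured compounds thus give no step size to carry over, and no direction can be read either.

The expectation for compound 4 is accordingly that it also reaches only the limit, and the estimated step of a number no higher from compound 2 to compound 4 (the limit leaves the size open) means essentially no readable change. Compound 4 is expected to give about 50000 nM in this assay, within a range from 25000 nM to 100000 nM.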

Compound 4, half-maximal inhibitory concentration: > 50000 nM
Compound 4 was reported as a limit (the forecaster's own chance of this, stated with the estimate: 80%); the middle value lies on the limit itself.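

Compound 4 ends at a limit too, so no step from compound 1, compound 2 or compound 3 to compound 4 can be read, and all four compounds share that same limit: the limit of > 50000 nM in this assay, at which 4 of the 4 values shown sit.

The compounds shown leave open whether fluoro, chloro, hydroxy or amino at this place differ at all in strength.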